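Stripping the Aryl Ketone from an Inactive Triazole Series

The source may report more compounds than this note shows. Statements on the series, on what has been measured and on what is new or still open speak of the compounds shown alone.

Compound 1 `Cc1nnc(SCC(=O)c2ccc(Cl)cc2)n1N1C(=O)c2ccccc2C1=O` was tested in a functional assay on MKN-45 cells (Homo sapiens) for cytotoxicity, read by MTT assay, with a stated time of 48 h; on this read-out lower numbers stand for stronger inhibition and higher numbers for weaker inhibition. In this assay compound 1 gives > 200000 nM, which is a limit of the assay rather than a measured number. Two close relatives are known. Compound 2 `Cc1ccc(C(=O)CSc2nnc(C)n2N2C(=O)c3ccccc3C2=O)cc1` gives > 200000 nM, again only a limit. Compound 3 `Cc1nnc(SCC(=O)c2ccccc2)n1N1C(=O)c2ccccc2C1=O` gives > 200000 nM, also a limit. The steps between these three, a step that the two limits leave unreadable from compound 1 to compound 2, a step that the two limits leave unreadable from compound 1 to compound 3 and a step that the two limits leave unreadable from compound 2 to compound 3, cannot be sized because of the limit of > 200000 nM in this assay, at which 3 of the 3 values shown sit.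

Compound 4 `CSc1nnc(C)n1N1C(=O)c2ccccc2C1=O` differs from compound 1 by hydrogen in place of (4-chlorophenyl)carbonyl on a saturated chain carbon bound to a sulfur. This is a larger change than any of the three measured steps, which each touched a single aromatic substituent, so none of them bears directly on it. Among the measured compounds shown here, what the three measured values do show is that every compound so far sits at the same limit, giving no sign of cytotoxicity to build on. Compound 4 is therefore expected to stay at or near that limit as well. The estimate for compound 4 is 300000 nM, within 100000 nM to 1000000 nM. That corresponds to an expected step that the limit leaves unreadable from compound 1 to compound 4.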

Compound 4, half-maximal inhibitory concentration: > 200000 nM
Compound 4: a limit, no number; the forecaster's own chance of this, stated with the estimate: 85%; the middle value is on the limit's open side.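

The steps from compound 1, compound 2 and compound 3 to compound 4 cannot be sized, because all four compounds rest on one limit, not on numbers: the limit of > 200000 nM in this assay, at which 4 of the 4 values shown sit.

Still open, as far as these compounds go, is whether any of these four compounds has a measurable effect in this assay at all, and so whether any of these changes matters.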